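A few compounds are considered here, and "the series" means these few. Any claim that something is new, unique, unknown or untested is made for them only; others in the source may bear on it.

Values in an in vitro ADME assay on microsomes from liver (Homo sapiens) for metabolic stability, read by HPLC; a lower number here means slower removal, a higher number faster removal of the compound:
- Compound 1 `NC(=O)[C@@H](CCC(F)(F)F)N(C[C@H]1CCCOC1)S(=O)(=O)c1ccc(Cl)cc1`: 156 mL/min/kg
- Compound 2 `NC(=O)[C@@H](CCC(F)(F)F)N(C[C@@H]1CCOC1)S(=O)(=O)c1ccc(Cl)cc1`: 69.8 mL/min/kg

Compound 2 has the lower number of the two. Compound 3 `NC(=O)[C@@H](CCC(F)(F)F)N(C[C@H]1CCCO1)S(=O)(=O)c1ccc(Cl)cc1` has the same atoms joined differently: oxolan-2-yl in place of oxolan-3-yl on a saturated chain carbon bound to a sulfonamide nitrogen. For the measured compounds named here, only one measured step offers any guide, a 2.2-fold lower number from compound 1 to compound 2 (0.35 log units; beyond the scatter), and it was modest. That step changed the ring itself, whereas here a five-membered ring stays and only its point of attachment moves, so it bears only loosely. A step no larger, and probably within the scatter, is expected in this assay, with the direction uncertain. The expected change is a 1.1-fold higher number from compound 2 to compound 3 (0.06 log units; within the scatter). The estimated value for compound 3 is 80 mL/min/kg, with an expected range of 40 mL/min/kg to 160 mL/min/kg.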

Compound 3, clearance: 231 mL/min/kg
For compound 3 the middle estimate is 2.9-fold (0.46 log units) below the measured one, and the stated range ends below it.
By their numbers in this assay, from the lowest: compound 2; then compounds 1 and 3 (each within the scatter of the next).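

Moving the point of attachment alone matters here: oxolan-2-yl in place of oxolan-3-yl gives a 3.3-fold higher number from compound 2 to compound 3 (0.52 log units; beyond the scatter) in this assay even though the ring size stays the same. Compound 1 and compound 3 cannot be told apart, with a 1.5-fold higher number from compound 1 to compound 3 (0.17 log units; within the scatter) as their step, so the lower number of compound 2 goes with the oxolan-3-yl attachment rather than with any five-membered ring. Nothing available explains the difference. Still open, going by these compounds, is whether an open methoxyethyl chain or a ring containing an amine, such as pyrrolidin-3-yl, would match compound 2 at this position.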